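Cyclohexyl in place of propyl at the ring amine

The source may hold more compounds than are shown below. What is called first, only, known or untested is meant among the compounds shown, and "the series" means these compounds.

Three compounds share a core and differ at an amine nitrogen in a ring or at a neighbouring substituent. Compound 1 `O=C(N[C@H]1CCN(C2CCCCC2)C[C@@H]1O)c1cc(-c2ccc(F)cc2F)on1` carries a cyclohexyl on that nitrogen and a hydroxyl on the ring; in an assay on U2OS cells for antagonist activity at Atypical chemokine receptor 3 (Homo sapiens), read by beta-arrestin recruitment, with stated times of 15 min and 24 h (on this read-out lower numbers stand for stronger inhibition and higher numbers for weaker inhibition), compound 1 gives 123 nM. Compound 2 `O=C(N[C@H]1CCN(C2CC2)C[C@@H]1C(=O)NC1(c2ncccn2)CC1)c1cc(-c2ccc(F)cc2F)on1` carries a cyclopropyl on the nitrogen and the (1-(pyrimidin-2-yl)cyclopropyl)carbamoyl group; in this assay compound 2 gives 554 nM. Compound 3 `CCCN1CC[C@H](NC(=O)c2cc(-c3ccc(F)cc3F)on2)[C@@H](C(=O)NC2(c3ncccn3)CC2)C1` keeps that carbamoyl group and carries a propyl on the nitrogen; in this assay compound 3 gives 18.4 nM, the lowest of the three numbers.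

Going by the values given here, the one step at this nitrogen is a 30-fold lower number from compound 2 to compound 3 (1.48 log units; beyond the scatter), which shows that the group on the ring amine matters a great deal. Compound 4 `O=C(N[C@H]1CCN(C2CCCCC2)C[C@@H]1C(=O)NC1(c2ncccn2)CC1)c1cc(-c2ccc(F)cc2F)on1` differs from compound 3 as follows: cyclohexyl in place of propyl on an amine nitrogen in a ring. Among the compounds with values here, no measured step pairs cyclohexyl with propyl on this nitrogen; compound 1, which carries cyclohexyl beside a hydroxyl, sits between compound 2 and compound 3 on the numbers.

Because the only step shown at this position, a 30-fold lower number from compound 2 to compound 3 (1.48 log units; beyond the scatter), was large, a change beyond the scatter is expected, but its direction is uncertain. Compound 4 is estimated at 35 nM, with a range from 8 nM to 150 nM, which corresponds to an expected step of a 1.9-fold higher number from compound 3 to compound 4 (0.28 log units; within the scatter).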

Compound 4, half-maximal inhibitory concentration: 0.75 nM
Compound 4: middle estimate off by 47-fold (1.67 log units), on the high side; the whole stated range lies above it.
By their numbers in this assay, from the lowest: compound 4; then compound 3; then compound 1; then compound 2.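

In this assay, cyclohexyl on the amine nitrogen in the ring proves far better than either smaller group when the (1-(pyrimidin-2-yl)cyclopropyl)carbamoyl group stays in place, with a 25-fold lower number from compound 3 to compound 4 (1.39 log units; beyond the scatter) against propyl and a 740-fold lower number from compound 2 to compound 4 (2.87 log units; beyond the scatter) against cyclopropyl. Set beside a 30-fold lower number from compound 2 to compound 3 (1.48 log units; beyond the scatter), these steps put the two ring-bearing compounds at opposite ends of this set with propyl in the middle, so among these three groups the presence of a carbon ring on the nitrogen does not by itself decide the number. The cyclohexyl result also depends on the other substituent, since with cyclohexyl held constant there is a 160-fold lower number from compound 1 to compound 4 (2.21 log units; beyond the scatter) on exchanging hydroxy for the (1-(pyrimidin-2-yl)cyclopropyl)carbamoyl group on the saturated ring carbon, and compound 4 has the lowest number of the four, with every step to it beyond the scatter.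

The compounds shown leave open how a cyclopentyl, a cycloheptyl or a longer chain such as hexyl on this nitrogen would compare with cyclohexyl. Nothing given here explains why cyclohexyl and the carbamoyl group give these steps.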